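Replacing the Basic Amine of Compound 1 with an Acid

The source may report more compounds than this note shows. Statements on the series, on what has been measured and on what is new or still open speak of the compounds shown alone.

Compound 1 `CCn1c(C(=O)NCCN(C)C)ccc1C(CC)(CC)c1ccc(OCCC(O)(CC)CC)c(C)c1`: 870 nM
Compound 2 `CCN(CC)CCNC(=O)c1ccc(C(CC)(CC)c2ccc(OCCC(O)(CC)CC)c(C)c2)n1CC`: 3350 nM
Compound 3 `CCn1c(C(=O)NCC#N)ccc1C(CC)(CC)c1ccc(OCCC(O)(CC)CC)c(C)c1`: 17800 nM

In a functional assay on PC-3 cells (Homo sapiens) for antiproliferative activity, read by MTT assay, with a stated time of 48 h (a lower number here means a stronger inhibitor, a higher number a weaker inhibitor), compound 1 gives 870 nM, the lowest of the three numbers measured. The step of a 3.9-fold higher number from compound 1 to compound 2 (0.59 log units; beyond the scatter) is modest, while the step of a 20-fold higher number from compound 1 to compound 3 (1.31 log units; beyond the scatter) is large, and between the two weaker compounds the step of a 5.3-fold higher number from compound 2 to compound 3 (0.73 log units; beyond the scatter) is again modest.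

Compound 4 `CCC(C)C(NC(=O)c1ccc(C(CC)(CC)c2ccc(OCCC(O)(CC)CC)c(C)c2)n1CC)C(=O)O` has not yet been measured. It differs from compound 1 in one place: 1-carboxy-2-methylbutyl in place of 2-(dimethylamino)ethyl on an amide-type nitrogen. The group that leaves is the same 2-(dimethylamino)ethyl whose exchanges in the two measured steps from compound 1 both gave higher numbers in this assay. The exchange for cyano, a group without the dimethylamino part, cost far more than the exchange for diethylamino, which kept a chain amine. Compound 4 also loses the chain amine and gains a carboxy group, so the expected step of a 23-fold higher number from compound 1 to compound 4 (1.36 log units; beyond the scatter) is a clearly higher number, in the region of compound 3 rather than compound 2. The estimate for compound 4 is therefore 20000 nM, with a range from 5000 nM to 80000 nM.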

Compound 4, half-maximal inhibitory concentration: 13800 nM
Compound 4: middle estimate off by 1.4-fold (0.16 log units), on the high side; low and high end bracket the measured number.
By their numbers in this assay, from the lowest: compound 1; then compound 2; then compounds 4 and 3 (each within the scatter of the next).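

In this assay, placing 1-carboxy-2-methylbutyl on the amide-type nitrogen gives a 16-fold higher number from compound 1 to compound 4 (1.20 log units; beyond the scatter) and also a 4.1-fold higher number from compound 2 to compound 4 (0.61 log units; beyond the scatter) so a side chain with a carboxy group and no chain amine stands well apart from both amine compounds. The entering group is quite unlike cyanomethyl in size and make-up, yet there is a 1.3-fold lower number from compound 3 to compound 4 (0.11 log units; within the scatter) so these two groups cannot be told apart in this assay. Across the four compounds, the two that keep a chain amine, compound 1 and compound 2, give lower numbers than the two without one, compound 3 and compound 4, and none of the four goes against this, although four compounds make only a small set.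

The compounds shown leave open whether the higher number of compound 4 follows from losing the amine, gaining the carboxylic acid, or the branched chain itself, and a methyl ester in place of the acid, or a dimethylamino group on the same branched chain, would help to separate these possibilities. Nothing measured here gives a cause for these numbers.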